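Oxanyl to hydroxycyclohexyl swap on the ring nitrogen

The compounds below may be only part of what the source reports. "The series", "measured", "known", "first", "only" and "open" are said of these compounds alone.

The series is followed in an ADME assay for permeability, using PAMPA, with a stated time of 30 min, at pH 7.4; on this read-out lower numbers stand for lower permeability and higher numbers for higher permeability. Compound 1 `Cc1c(C)n(Cc2ccccc2)c2ncn(C3CCOCC3)c(=N)c12` gives 1680 10^-6 cm/s in this assay, the highest of the two numbers shown. Compound 2 `COc1ccc(Cn2c(-c3ccccc3)c(-c3ccccc3)c3c(=N)n(CC4CCOCC4)cnc32)cc1` gives 1270 10^-6 cm/s in this assay, a value that sits within the scatter of compound 1, so no order between the two is claimed. Compound 3 `N=c1c2c(-c3ccccc3)c(-c3ccccc3)n(Cc3ccccc3)c2ncn1CCCN1CCN(c2ccccc2)CC1` returns only a limit of the assay, > 1000 10^-6 cm/s, and not a number; this is the limit of > 1000 10^-6 cm/s in this assay, at which 1 of the 3 values shown sits. The step of interest leads to compound 4 `Cc1c(C)n(Cc2ccccc2)c2ncn([C@H]3CC[C@H](O)CC3)c(=N)c12`, which differs from compound 1 by 4-hydroxycyclohexyl in place of oxan-4-yl on an aromatic nitrogen, in words 4-hydroxycyclohexyl in place of oxan-4-yl on an aromatic nitrogen. Among the measured compounds shown here, no measured pair shows this change, so nothing in the data fixes its size. The expected step from compound 1 to compound 4 is a 1.7-fold lower number from compound 1 to compound 4 (0.23 log units; within the scatter), a modest fall in this assay that may not clear the scatter. Compound 4 is therefore estimated at 1000 10^-6 cm/s, with a range from 500 10^-6 cm/s to 1700 10^-6 cm/s.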

Compound 4, apparent permeability: < 1 10^-6 cm/s
Compound 4 was reported as a limit; the forecaster's own chance of this, stated with the estimate: 20%; middle value at least 1000-fold (3.00 log units) away from the limit.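

In this assay, 4-hydroxycyclohexyl in place of oxan-4-yl on an aromatic nitrogen gives an at least 1600-fold lower number from compound 1 to compound 4 (3.22 log units; beyond the scatter), so a single change at this place is enough to take the read-out from the top of the measured values to the bottom. Among the compounds shown here, the earlier compounds offered no measured pair at this place, so this step is the first direct reading of how much it matters. Compound 4 stands at a limit of the assay and not at a number, which makes the size of the step a bound: the limit of < 1 10^-6 cm/s in this assay, at which 1 of the 4 values shown sits.

The compounds shown do not separate the hydroxyl gained from the ring oxygen lost, which a plain cyclohexyl, a 4-methoxycyclohexyl or a 4-aminocyclohexyl at this nitrogen would address. From the compounds shown here alone, whether the same swap has a similar outcome on the cores of compound 2 and compound 3 also stays open.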